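Adding a hydroxymethyl-thiazole to a soluble bicyclic core

The source may report more compounds than this note shows. Statements on the series, on what has been measured and on what is new or still open speak of the compounds shown alone.

Of the compounds shown here, two sharing one core have been measured in a physicochemical assay for solubility, in phosphate buffer, with a stated time of 18 h; a higher number here means a more soluble compound, a lower number a less soluble compound. Compound 1 `CC(C)(C)c1ncc2c(N)c(C#N)c(N)nc2n1` gives 37200 nM in this assay; this is the lowest of the two numbers seen so far, with compound 2 `CC(C)(C)c1nc(-c2ccncc2)c2c(N)c(C#N)c(N)nc2n1` nearest at 44000 nM. Among the measured compounds shown here, the single measured step, a 1.2-fold higher number from compound 1 to compound 2 (0.07 log units; within the scatter), lies within the scatter.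

Compound 3 `CC(C)(C)c1nc(-c2nc(CO)cs2)c2c(N)c(C#N)c(N)nc2n1` has not yet been measured. It differs from compound 1 by 4-(hydroxymethyl)-1,3-thiazol-2-yl in place of hydrogen on an aromatic carbon. For the measured compounds named here, the new group enters on an aromatic carbon of the shared core, the same carbon where compound 2 carries its pyridin-4-yl group, so the only measured step that bears on the question is a 1.2-fold higher number from compound 1 to compound 2 (0.07 log units; within the scatter), and that step was small. Going by the values given here, the entering group is a five-membered aromatic ring with 2 hetero atoms and carries 1 hydrogen-bond donor, but no measured pair shows what such a group does on this core. The expected change is therefore a 1.1-fold higher number from compound 1 to compound 3 (0.03 log units; within the scatter), no step beyond the scatter. Compound 3 is estimated at 40000 nM, with a range from 18000 nM to 90000 nM.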

Compound 3, solubility: < 1000 nM
Compound 3: no number, only a limit; the forecaster's own chance of this, stated with the estimate: 5%; at least 40-fold (1.60 log units) between middle value and limit.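

At this aromatic carbon of the shared core, the group that enters can matter a great deal: the change to 4-(hydroxymethyl)-1,3-thiazol-2-yl gives an at least 37-fold lower number from compound 1 to compound 3 (1.57 log units; beyond the scatter), whereas the earlier pyridin-4-yl step lay within the scatter. Exchanging one ring for the other on the same carbon gives an at least 44-fold lower number from compound 2 to compound 3 (1.64 log units; beyond the scatter), so these two aromatic rings are not interchangeable here, and a ring entering at this carbon does not by itself settle the outcome. Compound 3 has only a limit in this assay and not a number, so both steps give a smallest possible size and their true size stays unknown: the limit of < 1000 nM in this assay, at which 1 of the 3 values shown sits.

The compounds shown leave open whether the large step belongs to the 1,3-thiazol-2-yl ring or to the hydroxymethyl group on it; the two enter together in compound 3. A plain 1,3-thiazol-2-yl group, or the same ring with a methyl group or a carboxylic acid in place of the hydroxymethyl group, would help to separate the two parts, and a phenyl ring on this carbon would add a further comparison.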